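A Phenyl Swap on Compound 3

A few compounds are considered here, and "the series" means these few. Any claim that something is new, unique, unknown or untested is made for them only; others in the source may bear on it.

In a functional assay on HepG2 cells (Homo sapiens) for antiproliferative activity, read by CCK-8 assay, with a stated time of 24 h (on this read-out higher numbers stand for weaker inhibition and lower numbers for stronger inhibition), compound 1 (`COC(=O)[C@]1(Cc2ccc3c(c2)CC(O)C(C)(C)O3)OC(=O)C(O)=C1c1ccccc1`) gives > 20000 nM as a limit of the assay. Compound 2 (`CC(C)(O)C1Cc2cc(C[C@H]3OC(=O)C(O)=C3c3ccc(O)cc3)ccc2O1`) also gives > 20000 nM as a limit. Within the data shown here, compound 3 (`COC(=O)[C@]1(Cc2ccc(O)c(CC=C(C)C)c2)OC(=O)C(O)=C1c1ccc(O)c(CC=C(C)C)c1`) reads 9000 nM in this assay and so holds the only actual number of the three. Compound 4 (`COC(=O)[C@]1(Cc2ccc(O)c(CC=C(C)C)c2)OC(=O)C(O)=C1c1ccccc1`), not yet measured, has phenyl in place of 4-hydroxy-3-(3-methylbut-2-en-1-yl)phenyl on a double-bonded ring carbon. Among the measured compounds shown here, no measured step gauges this change directly. Weaker inhibition is expected, and the limit of > 20000 nM in this assay, at which 2 of the 3 values shown sit, may well be reached. The expected step of a 2.2-fold higher number from compound 3 to compound 4 (0.35 log units; beyond the scatter) is of modest size and runs toward weaker inhibition. Compound 4 is estimated at 20000 nM with 9000 nM to 45000 nM as its expected range.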

Compound 4, half-maximal inhibitory concentration: 12900 nM
Beside the measured number, compound 4's estimate is 1.6-fold (0.19 log units) above it, and the stated range covers the measured number.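

In this assay, replacing 4-hydroxy-3-(3-methylbut-2-en-1-yl)phenyl with phenyl on the double-bonded ring carbon gives a 1.4-fold higher number from compound 3 to compound 4 (0.16 log units; within the scatter). The hydroxy group and the 3-methylbut-2-en-1-yl chain of that aryl group can therefore both leave this position together without a shift beyond the scatter. Compound 4 also keeps a real number rather than falling to the assay limit: the limit of > 20000 nM in this assay, at which 2 of the 4 values shown sit.

Going by these compounds, it remains open how a phenyl bearing an amine or a carboxylic acid would read at this position. On these data alone, the role of the 3-methylbut-2-en-1-yl chain that compound 3 and compound 4 still share elsewhere also remains open.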